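Replacing a Methoxyphenyl Group: An Estimate for Compound 4

A few compounds are considered here, and "the series" means these few. Any claim that something is new, unique, unknown or untested is made for them only; others in the source may bear on it.

Three compounds have been measured in a functional assay on HT-29 cells (Homo sapiens) for antiproliferative activity, read by sulforhodamine B assay, with a stated time of 72 h; a higher number here means a weaker inhibitor, a lower number a stronger inhibitor:

compound 1 `COc1cccc(NC(=S)N/N=C/c2ccc3ccccc3n2)c1` gives 82400 nM
compound 2 `Cc1csc2sc(/C=N/NC(N)=S)c(C)c12` gives 57500 nM
compound 3 `CC(C)c1cccc(C(C)C)c1NC(=S)N/N=C/c1ccc2ccccc2n1` gives 20700 nM

Compound 1 stands at the highest of the three numbers. Its value and that of compound 2 lie within the usual scatter of each other, so nothing separates them. Compound 3 is the one that lies beyond the scatter from compound 1, with the lower number of the two.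

Compound 4 `S=C(N/N=C/c1ccc2ccccc2n1)Nc1ccccc1Br` has not yet been measured in this assay. It differs from compound 1 in a single place: 2-bromophenyl in place of 3-methoxyphenyl on an amide-type nitrogen. For the measured compounds named here, no pair of measured compounds isolates this change, so its effect cannot be read off directly; compound 3 only shows that a different substituent on the same amide-type nitrogen can move the number beyond the scatter.

The step from compound 1 to compound 4 is therefore expected to be modest, most likely toward a somewhat lower number, as in a 1.5-fold lower number from compound 1 to compound 4 (0.18 log units; within the scatter), and it may well fall within the scatter. Compound 4 is estimated to give 55000 nM in this assay, with a range from 18000 nM to 150000 nM.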

Compound 4, half-maximal inhibitory concentration: > 100000 nM
Compound 4: no number, only a limit (the forecaster's own chance of this, stated with the estimate: 15%); middle value at least 1.8-fold (0.25 log units) away from the limit.
By their numbers in this assay, from the lowest: compound 3; then compounds 2 and 1 (each within the scatter of the next). At a limit, above all of these: compound 4.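

In this assay compound 4 gives > 100000 nM, which is a limit of the assay and not a number. On the amide-type nitrogen, 2-bromophenyl in place of 3-methoxyphenyl brings no lower number: the change gives an at least 1.2-fold higher number from compound 1 to compound 4 (0.08 log units; that floor lies within the scatter). So although compound 3 showed that a different substituent at this place can go with a lower number, this swap did not, and the floor of the step lies within the scatter, which leaves its true size unknown and the reading resting on one open-ended value: the limit of > 100000 nM in this assay, at which 1 of the 4 values shown sits.

The compounds shown leave open whether this outcome follows from the bromine itself or from where it sits on the phenyl ring, since the two differences arrive together in this one change. A 3-bromophenyl or a 2-methoxyphenyl group on the same nitrogen would separate them, and a plain phenyl group would give a reference for every substituent at this place.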